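From compound 2 to compound 4: working notes

This account rests on a few compounds, and the source may have more. Where it says the series, first, only, none or still open, it means among the compounds named here.

In an ADME assay on tissue (MDA-MB-231 cells, Homo sapiens) for pharmacokinetics (on this read-out lower numbers stand for a shorter-lived compound and higher numbers for a longer-lived compound), compound 2 `N[C@@H](CC(=O)OC[C@H]1O[C@@H](n2cc(F)c(=O)[nH]c2=O)C[C@@H]1O)C(=O)O` gives 0.185 h. That value lies within the scatter of its two measured relatives: compound 1 `N[C@@H](CCC(=O)OC[C@H]1O[C@@H](n2cc(F)c(=O)[nH]c2=O)C[C@@H]1OC(=O)CC[C@H](N)C(=O)O)C(=O)O` gives 0.352 h and compound 3 `N[C@@H](CC(=O)OC[C@H]1O[C@@H](n2cc(F)c(=O)[nH]c2=O)C[C@@H]1OC(=O)C[C@H](N)C(=O)O)C(=O)O` gives 0.155 h.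

Compound 4 `CC(C)[C@H](N)C(=O)OC[C@H]1O[C@@H](n2cc(F)c(=O)[nH]c2=O)C[C@@H]1O` differs from compound 2 as follows: 1-amino-2-methylpropyl in place of 2-amino-2-carboxyethyl on a carbonyl carbon. In words, 1-amino-2-methylpropyl stands in place of 2-amino-2-carboxyethyl on a carbonyl carbon. Among the compounds with values here, no measured step makes this exchange. The nearest guide is a different change, a 1.2-fold lower number from compound 2 to compound 3 (0.08 log units; within the scatter), which stayed within the scatter. No step beyond the scatter is therefore expected in this assay, and the expected step is a 1.2-fold higher number from compound 2 to compound 4 (0.08 log units; within the scatter). For compound 4 the estimated value is 0.22 h, with an expected range of 0.1 h to 0.5 h.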

Compound 4, half-life: 0.255 h
Estimate against measurement, compound 4: 1.2-fold (0.06 log units) below; measured number inside the range.
By their numbers in this assay, from the lowest: compounds 3, 2, 4 and 1 (each within the scatter of the next, the first and the last beyond it).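

In this assay, within the data shown here, the first exchange on this carbonyl carbon itself gives a 1.4-fold higher number from compound 2 to compound 4 (0.14 log units; within the scatter) and so stays within the scatter. The side chain here can therefore pass from 2-amino-2-carboxyethyl to 1-amino-2-methylpropyl, which has no oxygen, without a step beyond the scatter. No evidence bears on this result. As far as these compounds go, whether a side chain lacking the amine, or a longer chain on this carbonyl carbon, stays within the scatter remains open. So does the step for (1-amino-2-methylpropyl)carbonyl in place of hydrogen on the oxygen on a saturated carbon of compound 4.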